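The source may report more compounds than this note shows. Statements on the series, on what has been measured and on what is new or still open speak of the compounds shown alone.

Measured compounds and their values:

Compound 1 `Fc1ccccc1CSc1nnc(-c2cnccn2)s1`: 18400 nM
Compound 2 `Clc1ccccc1CSc1nnc(-c2cnccn2)s1`: 20300 nM
Compound 3 `Fc1ccc(CSc2nnc(-c3cnccn3)n2-c2ccccc2)cc1`: 27200 nM

All three were tested in a functional assay on BGC-823 cells (Homo sapiens) for antiproliferative activity, read by MTT assay, with a stated time of 48 h; on this read-out lower numbers stand for stronger inhibition and higher numbers for weaker inhibition. Compound 1 and compound 2 share a core and differ only by chloro in place of fluoro on an aromatic carbon; that change gave a 1.1-fold higher number from compound 1 to compound 2 (0.04 log units; within the scatter). Compound 3 has a different core; how its core differs from that of compound 1 is not broken down here. Its value sits near the other two.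

Compound 4 `Clc1ccc(CSc2nnc(-c3cnccn3)n2-c2ccccc2)cc1` has not yet been measured. It differs from compound 3 by chloro in place of fluoro on an aromatic carbon. Within the data shown here, this is the same kind of change as the one from compound 1 to compound 2, but the place is not identical: in that earlier pair the change sits "ortho to a large group", whereas here it sits "para to a large group".

Because the earlier change gave a 1.1-fold higher number from compound 1 to compound 2 (0.04 log units; within the scatter), a similarly small step is expected from compound 3 to compound 4, about a 1.1-fold higher number from compound 3 to compound 4 (0.04 log units; within the scatter). On that basis compound 4 is estimated at 30000 nM in this assay, with a likely range from 15000 nM to 60000 nM.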

Compound 4, half-maximal inhibitory concentration: 27700 nM
Estimate against measurement, compound 4: 1.1-fold (0.03 log units) above; measured number inside the range.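

In this assay, going from 4-fluorobenzyl to 4-chlorobenzyl gave a 1.0-fold higher number from compound 3 to compound 4 (0.01 log units; within the scatter), so on this core too the swap of one halogen for the other has no readable effect. Set side by side, the two cores agree for this change: the same change on two cores in this assay, a 1.1-fold higher number (0.04 log units; within the scatter) from compound 1 to compound 2 and a 1.0-fold higher number (0.01 log units; within the scatter) from compound 3 to compound 4, 1.1-fold (0.03 log units) apart, within the scatter of two such steps This shows that a swap with no readable effect on one core also had none on the other, but it does not show that the result would hold on any further core, and since the change also sits at a different place on the ring in each pair, the role of the core cannot be separated from that of the place.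

The compounds shown leave open whether a group other than these two halogens, such as methoxy, an amine or a carboxylic acid, would shift the number on either core. They also leave open whether a longer chain in place of the benzyl group would do so.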